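The source may hold more compounds than are shown below. What is called first, only, known or untested is meant among the compounds shown, and "the series" means these compounds.

In a functional assay on HepG2 cells (Homo sapiens) for cytotoxicity, with a stated time of 24 h (a higher number here means a weaker inhibitor, a lower number a stronger inhibitor), two compounds have been measured so far. Compound 1 `O=C(N/N=C/c1cc(I)cc(I)c1O)c1ccc([N+](=O)[O-])cc1` gives 24700 nM. Compound 2 `COc1ccc(C(=O)N/N=C/c2cc(I)c(O)c(I)c2)cc1` reaches only the limit of this assay, > 100000 nM, so for compound 2 a bound is known rather than a number. That bound is where compound 2 stands: the limit of > 100000 nM in this assay, at which 1 of the 2 values shown sits. Among the measured compounds shown here, no single change links compound 1 and compound 2, so their two values show only that compound 2 was too weak to be pinned down while compound 1 was not.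

Compound 3 `O=C(N/N=C/c1cc(I)c(O)c(I)c1)c1ccc(I)cc1` follows from compound 2 by one replacement, (iodo in place of methoxy on an aromatic carbon), that is, iodo in place of methoxy on an aromatic carbon. For the measured compounds named here, no measured pair shows what this swap does in this assay, so the size of the step is open; a modest move toward a stronger inhibitor, or none beyond the usual scatter, both seem possible. Compound 3 is therefore expected to give about 60000 nM, with a range from 20000 nM to 200000 nM. This estimate means a step of an at least 1.6-fold lower number from compound 2 to compound 3 (0.22 log units; that floor lies within the scatter), and a result reported only as a limit would not be surprising.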

Compound 3, half-maximal inhibitory concentration: > 50000 nM
Compound 3: no number, only a limit (the forecaster's own chance of this, stated with the estimate: 45%); the middle value lies beyond the limit too.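

For compound 3 the result of > 50000 nM is a limit of this assay and not a number. For compound 2 the result of > 100000 nM is also a limit, so no step can be read between compound 2 and compound 3. Going by these compounds, what iodo in place of methoxy on an aromatic carbon does to cytotoxicity remains open.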